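The compounds below may be only part of what the source reports. "The series", "measured", "known", "first", "only" and "open" are said of these compounds alone.

Working notes on the series. Three compounds share one core and differ only in the group on a saturated ring carbon. Compound 1 `COc1cc(N2C(N)=C(C#N)C(c3ccc(OC)c4ccccc34)C3=C2CC(C)(C)CC3=O)cc(OC)c1OC` gives 40% in a functional assay on Ehrlich cells (Mus musculus) for cytotoxicity, tested at 100 ug/mL; a lower number here means a weaker effect, a higher number a stronger effect of the compound at the concentration tested. Compound 2 `COc1cc(N2C(N)=C(C#N)C(c3cccc([N+](=O)[O-])c3)C3=C2CC(C)(C)CC3=O)cc(OC)c1OC` gives 30% in this assay. Compound 3 `COc1cc(N2C(N)=C(C#N)C(c3ccc([N+](=O)[O-])cc3)C3=C2CC(C)(C)CC3=O)cc(OC)c1OC` gives 80% in this assay, the highest of the three numbers, with both other compounds beyond the scatter from it.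

The steps between them are a number 10 percentage points lower from compound 1 to compound 2 (within the scatter), a number 40 percentage points higher from compound 1 to compound 3 (beyond the scatter) and a number 50 percentage points higher from compound 2 to compound 3 (beyond the scatter). Among the compounds with values here, only the step to the 4-nitrophenyl compound moved the number; the other exchange stayed within the scatter.

Compound 4 `COc1cc(N2C(N)=C(C#N)C(c3cccs3)C3=C2CC(C)(C)CC3=O)cc(OC)c1OC` is not yet measured. Its change from compound 3: thiophen-2-yl in place of 4-nitrophenyl on a saturated ring carbon. Within the data shown here, no measured step involves thiophen-2-yl, so the relevant comparisons are the two large steps into compound 3 and the flat step between compound 1 and compound 2. Since two of three aryl groups at this position gave the lower numbers and only 4-nitrophenyl gave the high one, a step down is expected, as a number 35 percentage points lower from compound 3 to compound 4 (beyond the scatter). Compound 4 is therefore estimated at 45%, in the range 20% to 75%.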

Compound 4, a percentage reported as activity, at one concentration (the size of the read-out at that concentration, not a potency): 20%
The estimate for compound 4 lay 25 percentage points above the measured number; the measured number falls inside the stated range.
By their numbers in this assay, from the lowest: compounds 4, 2 and 1 (each within the scatter of the next, the first and the last beyond it); then compound 3.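

Thiophen-2-yl, the first five-membered aromatic ring with a hetero atom at this position, does not keep the high number in this assay: a number 60 percentage points lower from compound 3 to compound 4 (beyond the scatter), leaving 4-nitrophenyl as the only group shown that reaches it. Set against the other two groups, the new ring gives a number 10 percentage points lower from compound 2 to compound 4 (within the scatter) and a number 20 percentage points lower from compound 1 to compound 4 (beyond the scatter), so it stands apart from 4-methoxynaphthalen-1-yl but not from 3-nitrophenyl, which also lies within the scatter of 4-methoxynaphthalen-1-yl. Nothing available explains why 4-nitrophenyl stands apart from the other three groups.

The compounds shown leave open whether the high number belongs to the nitro group itself or would also appear with 4-aminophenyl, 4-chlorophenyl or 4-carboxyphenyl in the same place. They also leave open whether furan-2-yl or pyridin-4-yl would behave like thiophen-2-yl.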